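The source may report more compounds than this note shows. Statements on the series, on what has been measured and on what is new or still open speak of the compounds shown alone.

Compound 1 `C=CCn1c(=O)n(C2C=CC(CO)O2)c2nc(N)nc(O)c21` gives the lowest number among the three measured compounds. In a functional assay on YAC-1 cells (Mus musculus) for activation (a lower number here means that less compound is needed, a higher number that more compound is needed for the effect), compound 1 gives 11 uM. Compound 2 `C=CCn1c(=S)n([C@@H]2O[C@H](CO)[C@H]3OC(C)(C)O[C@H]32)c2nc(N)nc(O)c21` gives 40 uM in this assay, a higher number than compound 1 by more than the usual scatter. Compound 3 `Nc1nc(O)c2c(n1)n(C1OC(CO)[C@@H](O)[C@H]1O)c(=O)n2Cc1ccc(Cl)c(Cl)c1` gives 110 uM in this assay, the highest of the three. Compound 4 `CCCn1c(=O)n(C2C=CC(CO)O2)c2nc(N)nc(O)c21` differs from compound 1 in one place: ethyl in place of vinyl on a saturated chain carbon bound to an aromatic nitrogen. This swaps one small chain for another of the same length, and the rest of the molecule stays the same. Such a change is expected to move the number in this assay little, perhaps not beyond the scatter in either direction. Compound 4 is therefore estimated at 15 uM, with a range from 5 uM to 45 uM, a step of a 1.4-fold higher number from compound 1 to compound 4 (0.13 log units; within the scatter).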

Compound 4, concentration for half-maximal effect: 14 uM
For compound 4 the middle estimate is 1.1-fold (0.03 log units) above the measured one, and the stated range covers the measured number.
By their numbers in this assay, from the lowest: compounds 1 and 4 (each within the scatter of the next); then compound 2; then compound 3.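

In this assay, putting ethyl in place of vinyl on a saturated chain carbon bound to an aromatic nitrogen gives a 1.3-fold higher number from compound 1 to compound 4 (0.10 log units; within the scatter). This is the first pair shown that differs in one place, and it indicates that the double bond outside aromatic rings can be removed from this chain with the two numbers staying within the scatter of each other. No measurement at hand bears on why the two compounds match. The compounds shown leave open how a longer chain such as butyl, or a chain ending in an amine or a carboxylic acid, would read at this position.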